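The source may hold more compounds than are shown below. What is called first, only, known or untested is meant among the compounds shown, and "the series" means these compounds.

Measured so far in an assay on CHO cells for binding affinity to Alpha-2B adrenergic receptor (Homo sapiens), read by radioligand binding; on this read-out higher numbers stand for weaker inhibition and lower numbers for stronger inhibition:
Compound 1, `CSc1ccc(F)cc1NCC1=NCCN1`, gives 331 nM.
Compound 2, `CS(=O)(=O)c1ccc(Cl)cc1NCC1=NCCN1`, gives only the limit < 6310 nM.
Compound 3, `CS(=O)(=O)c1ccc(F)cc1NCC1=NCCN1`, gives only the limit < 6310 nM.

Compound 3 thus stands at a limit and not at a number, (the limit of < 6310 nM in this assay, at which 2 of the 3 values shown sit). Only compound 1 carries a number. Both steps that lead into compound 3 are unreadable for that reason: a step that the limit leaves unreadable from compound 1 to compound 3 and a step that the two limits leave unreadable from compound 2 to compound 3. Compound 4, `COc1ccc(S(C)(=O)=O)c(NCC2=NCCN2)c1`, differs from compound 3 by methoxy in place of fluoro on an aromatic carbon. Among the measured compounds shown here, no measured step bears on a methoxy, and the two steps into compound 3 give no size, so nothing sets a direction for this change. The step is expected to be a step that the limit leaves unreadable from compound 3 to compound 4, with no direction claimed beyond the scatter. Compound 4 is estimated at 2000 nM, within 400 nM to 10000 nM, and a reading that is again only a limit is likely.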

Compound 4, inhibition constant: < 6310 nM
Compound 4 gave a limit, no number; the forecaster's own chance of this, stated with the estimate: 60%; the middle value is on the limit's open side.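

No step can be read from compound 2 or compound 3 to compound 4, since all three stand at a limit: the limit of < 6310 nM in this assay, at which 3 of the 4 values shown sit. The compounds shown leave open whether chloro, fluoro and methoxy differ at all in compound 2, compound 3 and compound 4.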